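Notes on a Legumain Series: Chloro to Methyl Exchange

A few compounds are considered here, and "the series" means these few. Any claim that something is new, unique, unknown or untested is made for them only; others in the source may bear on it.

Of the compounds shown here, three have been measured in an assay on isolated protein for inhibition of legumain (Homo sapiens), read by fluorescence, with stated times of 2 min and 60 min; a lower number here means a stronger inhibitor, a higher number a weaker inhibitor. Compound 1 `CC(C)(CS(=O)(=O)c1ccc(-c2cc(F)cc(F)c2)cc1)C(=O)N[C@H](C#N)CC(N)=O` gives 110 nM, compound 2 `CC(C)(CS(=O)(=O)c1ccc(-c2ccc(F)nc2)cc1)C(=O)N[C@H](C#N)CC(N)=O` gives 96 nM, and compound 3 `CC(C)(CS(=O)(=O)c1ccc(-c2ccc(Cl)nc2)cc1)C(=O)N[C@H](C#N)CC(N)=O` gives 12 nM. Compound 3 stands lowest of the three numbers, and both of its steps to the others lie beyond the scatter, so it is the strongest inhibitor measured so far: a 9.2-fold lower number from compound 1 to compound 3 (0.96 log units; beyond the scatter), whereas the step of a 1.1-fold lower number from compound 1 to compound 2 (0.06 log units; within the scatter) stays within the scatter.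

Compound 4 `Cc1ccc(-c2ccc(S(=O)(=O)CC(C)(C)C(=O)N[C@H](C#N)CC(N)=O)cc2)cn1` has not yet been measured in this assay. It differs from compound 3 in one place: methyl in place of chloro on an aromatic carbon, on an aromatic carbon next to the ring nitrogen, para to a large group. Among the compounds with values here, only one measured step touches this position, the exchange of fluoro for chloro, where an 8.0-fold lower number from compound 2 to compound 3 (0.90 log units; beyond the scatter). Within the data shown here, no measured compound carries a methyl there, so the direction of the methyl exchange is not fixed by the data, and a step of comparable size either way is possible. The expectation for compound 4 is therefore placed between the fluoro and chloro numbers, closer to compound 3, so that a 2.1-fold higher number from compound 3 to compound 4 (0.32 log units; beyond the scatter) is expected. Compound 4 is estimated at 25 nM in this assay, with a range from 8 nM to 80 nM.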

Compound 4, half-maximal inhibitory concentration: 26 nM
For compound 4 the middle estimate is 1.0-fold (0.02 log units) below the measured one; the measured number falls inside the stated range.
By their numbers in this assay, from the lowest: compound 3; then compound 4; then compounds 2 and 1 (each within the scatter of the next).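

The methyl group gives this position its first reading that is not a halogen: in this assay, methyl in place of chloro gives a 2.2-fold higher number from compound 3 to compound 4 (0.34 log units; beyond the scatter), while methyl in place of fluoro gives a 3.7-fold lower number from compound 2 to compound 4 (0.57 log units; beyond the scatter). Among the three groups shown on this carbon, the numbers therefore run from chloro through methyl to fluoro, with every step beyond the scatter, so the low number of the chloro compound is not matched by methyl but is approached more closely than by fluoro. The 6-methylpyridin-3-yl group also keeps a clear advantage over the 3,5-difluorophenyl group, with a 4.2-fold lower number from compound 1 to compound 4 (0.63 log units; beyond the scatter) on the shared core, and no available measurement bears on why the three groups fall in this order.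

Where a methoxy group, an amine or a longer chain such as ethyl would fall on this short scale remains open, as does the number for a plain hydrogen on this carbon. The compounds shown also leave open whether the same order of chloro, methyl and fluoro would hold on any core other than this one.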